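The source may report more compounds than this note shows. Statements on the series, on what has been measured and on what is new or still open speak of the compounds shown alone.

Measured so far:
compound 1 `COc1ccc(-c2cnc(C(=O)CCCCCCc3ccccc3)o2)cc1` gives 100 nM
compound 2 `O=C(CCCCCCc1ccccc1)c1ncc(-c2cc(C(F)(F)F)ccn2)o1` gives 3.5 nM

In an assay (Rattus norvegicus) for inhibition of Fatty-acid amide hydrolase 1 (Homo sapiens) (on this read-out lower numbers stand for stronger inhibition and higher numbers for weaker inhibition), compound 1 stands at the higher of the two numbers, and compound 2 lies beyond the usual scatter below it. Compound 3 `O=C(CCCCCCc1ccccc1)c1ncc(I)o1` has not yet been measured. It differs from compound 1 by iodo in place of 4-methoxyphenyl on an aromatic carbon. For the measured compounds named here, no measured pair shows exactly this exchange, so the expectation rests on a judgment: swapping a whole 4-methoxyphenyl group for a single iodo group is expected to cost some inhibition, a step of a 3.0-fold higher number from compound 1 to compound 3 (0.48 log units; beyond the scatter) in the direction of higher numbers. Compound 3 is therefore estimated at 300 nM, within a range of 60 nM to 1500 nM.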

Compound 3, inhibition constant: 3 nM
Compound 3: middle estimate off by 100-fold (2.00 log units), on the high side, outside the stated range (below it).
By their numbers in this assay, from the lowest: compounds 3 and 2 (each within the scatter of the next); then compound 1.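

At this ring carbon next to the ring oxygen, iodo in place of 4-methoxyphenyl brings a 33-fold lower number from compound 1 to compound 3 (1.52 log units; beyond the scatter) in this assay. An aromatic ring on this carbon is therefore not needed for strong inhibition, and a single iodine atom serves far better here than the 4-methoxyphenyl group. No measurement shown explains this gain. From the compounds shown here alone, it remains open whether the gain belongs to iodo itself or comes simply from losing the 4-methoxyphenyl group. A plain hydrogen, chloro or an amine on this carbon would separate those two readings.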